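The source may hold more compounds than are shown below. What is called first, only, known or untested is meant among the compounds shown, and "the series" means these compounds.

For the measured compounds named here, compound 1 `CCCCOc1c(-c2cc(OC)c(OC)c(OC)c2)oc2ccccc2c1=O` gives 8900 nM in a functional assay on LNCaP cells (Homo sapiens) for antiproliferative activity, read by WST assay, with a stated time of 3 days (a higher number here means a weaker inhibitor, a lower number a stronger inhibitor), the highest of the two numbers measured so far. Compound 2 `CCCCCN(CCCCC)CCCOc1c(-c2cc(OC)c(OC)c(OC)c2)oc2ccccc2c1=O` gives 5100 nM in this assay, and the step of a 1.7-fold lower number from compound 1 to compound 2 (0.24 log units; within the scatter) stays within the scatter. Compound 3 `CCCCCN(CCCCC)CCCCOc1c(-c2cc(OC)c(OC)c(OC)c2)oc2ccccc2c1=O` differs from compound 1 by dipentylamino in place of hydrogen on a saturated chain carbon, four bonds along the chain from an oxygen on an aromatic ring. Going by the values given here, the only measured step that bears on this change is the one from compound 1 to compound 2, and since it was small, a similarly small shift, if any, is expected here. Compound 3 is therefore estimated at 5500 nM, with a range from 2500 nM to 12000 nM, a step of a 1.6-fold lower number from compound 1 to compound 3 (0.21 log units; within the scatter) that is expected to lie within the scatter.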

Compound 3, half-maximal inhibitory concentration: 9700 nM
Estimate against measurement, compound 3: 1.8-fold (0.25 log units) below; measured number inside the range.
By their numbers in this assay, from the lowest: compounds 2, 1 and 3 (each within the scatter of the next).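

In this assay, dipentylamino on a saturated chain carbon, four bonds along the chain from an oxygen on an aromatic ring, stays within the scatter of the plain chain (a 1.1-fold higher number from compound 1 to compound 3 (0.04 log units; within the scatter)). (Dipentylamino)methyl in place of dipentylamino also stays within the scatter (a 1.9-fold higher number from compound 2 to compound 3 (0.28 log units; within the scatter)), so at neither chain length does the amine separate from compound 1. No supporting measurement bears on why these numbers stay so close. From the compounds shown here alone, whether dimethylamino, a piperidine or a carboxylic acid in place of dipentylamino would give a step beyond the scatter stays open.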